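Aryl groups on the ring nitrogen: next step to compound 4

The compounds below may be only part of what the source reports. "The series", "measured", "known", "first", "only" and "open" are said of these compounds alone.

Measured so far in this series:
compound 1 `CC(C)N1CCN(Cc2csc(N)c2C(=O)c2ccc(Cl)cc2)CC1`, -7.4%
compound 2 `Nc1scc(CN2CCN(c3ccc(Cl)cc3Cl)CC2)c1C(=O)c1ccc(Cl)cc1`, -74%
compound 3 `Nc1scc(CN2CCN(c3cccc(C(F)(F)F)c3)CC2)c1C(=O)c1ccc(Cl)cc1`, -80%

All three numbers come from a functional assay on CHO cells with adenosine receptor A1 (Homo sapiens) as the target, read by cAMP accumulation and immunoassay, with a stated time of 6 min, tested at 10 uM; on this read-out lower numbers stand for a stronger effect and higher numbers for a weaker effect at the one concentration tested. Compound 1 stands highest of the three. The nearest to it is compound 2, reached by a number 66.6 percentage points lower from compound 1 to compound 2 (beyond the scatter); the furthest is compound 3, reached by a number 72.6 percentage points lower from compound 1 to compound 3 (beyond the scatter). Between the two aryl-bearing compounds the step is a number 6 percentage points lower from compound 2 to compound 3 (within the scatter), so compound 2 and compound 3 sit within the scatter of each other.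

Compound 4 `Nc1scc(CN2CCN(c3ccncc3)CC2)c1C(=O)c1ccc(Cl)cc1` is not yet measured. It differs from compound 1 thus: pyridin-4-yl in place of isopropyl on an amine nitrogen in a ring. Among the measured compounds shown here, the steps that bear on it are those from compound 1 to compound 2 and from compound 1 to compound 3: in both, isopropyl on the same ring nitrogen gives way to a six-membered aromatic ring, and both steps are large and downward. Pyridin-4-yl is likewise a six-membered aromatic ring at that place, but with one hetero atom in the ring, which neither measured aryl group carries; no measured step covers that feature. A downward step beyond the scatter is therefore expected, with room for it to be smaller than the two measured ones. The expected step is a number 42.6 percentage points lower from compound 1 to compound 4 (beyond the scatter). For compound 4 the estimate is -50%, within -85% to -10%.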

Compound 4, a percentage reported as activity, at one concentration (the size of the read-out at that concentration, not a potency): -15%
Compound 4: middle estimate off by 35 percentage points, on the low side; measured number inside the range.
By their numbers in this assay, from the lowest: compounds 3 and 2 (each within the scatter of the next); then compounds 4 and 1 (each within the scatter of the next).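

In this assay, a six-membered aromatic ring on the amine nitrogen does not by itself bring the large downward step seen with the two earlier aryl groups: pyridin-4-yl in place of isopropyl gives a number 7.6 percentage points lower from compound 1 to compound 4 (within the scatter), so this read-out does not separate those two groups. The differences among the aromatic rings at this place are large, with pyridin-4-yl in place of 3-(trifluoromethyl)phenyl giving a number 65 percentage points higher from compound 3 to compound 4 (beyond the scatter) and pyridin-4-yl in place of 2,4-dichlorophenyl giving a number 59 percentage points higher from compound 2 to compound 4 (beyond the scatter), so among the four compounds the identity of the ring matters here, not merely the presence of one. Nothing in the available data gives a reason for this split.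

The compounds shown do not tell whether the ring nitrogen of pyridin-4-yl or the lack of any substituent on its ring sets compound 4 apart from the two aryl compounds. Unsubstituted phenyl on the same amine nitrogen would bear on that question, as would pyridin-3-yl or a pyridin-4-yl ring carrying chlorine or trifluoromethyl.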